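The compounds below may be only part of what the source reports. "The series", "measured", "known", "first", "only" and "open" are said of these compounds alone.

Compounds measured in a functional assay on V79 cells (Cricetulus griseus) for cytotoxicity, read by colony formation; a higher number here means a weaker inhibitor, a lower number a stronger inhibitor:
compound 1, `NCC1CCN(c2c(F)cc3c(=O)c(C(=O)O)cn(C4CC4)c3c2F)C1`, 11 ug/mL
compound 2, `NCC1CCN(c2c(F)cc3c(=O)c(C(=O)O)cn(C4CC4)c3c2Cl)C1`, 8 ug/mL
compound 3, `O=C(O)c1cn(C2CC2)c2c(F)c(N3CCNCC3)c(F)cc2c1=O`, 47 ug/mL

Compound 1 carries the core shared by all three, and compound 3 differs from it in one place: piperazin-1-yl in place of 3-(aminomethyl)pyrrolidin-1-yl on an aromatic carbon. That change gave a 4.3-fold higher number from compound 1 to compound 3 (0.63 log units; beyond the scatter), and compound 3 ends with the highest number of the three, beyond the scatter from both compound 1 and compound 2. Compound 2 differs from compound 1 in one place as well: chloro in place of fluoro on an aromatic carbon. The step it made was a 1.4-fold lower number from compound 1 to compound 2 (0.14 log units; within the scatter), so in this assay compound 1 and compound 2 cannot be told apart.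

Compound 4, `O=C(O)c1cn(C2CC2)c2c(Cl)c(N3CCNCC3)c(F)cc2c1=O`, has not yet been measured. It stands to compound 3 as compound 2 stands to compound 1: chloro in place of fluoro on an aromatic carbon. The two changes are the same kind of change but not the same, for the place differs in its surroundings: in compound 1 it is ortho to a 3-(aminomethyl)pyrrolidin-1-yl group (7 heavy atoms), in compound 3 it is ortho to a piperazin-1-yl group (6 heavy atoms).

The expectation for compound 4 in this assay rests on compound 1 and compound 2, where the same kind of change gave a 1.4-fold lower number from compound 1 to compound 2 (0.14 log units; within the scatter). A step of about a 1.3-fold lower number from compound 3 to compound 4 (0.13 log units; within the scatter) is therefore expected from compound 3 to compound 4, within the scatter. Compound 4 is thus estimated at 35 ug/mL, with a range from 15 ug/mL to 80 ug/mL.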

Compound 4, half-maximal inhibitory concentration: 43 ug/mL
Beside the measured number, compound 4's estimate is 1.2-fold (0.09 log units) below it; the range from low to high includes it.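

In this assay, chloro in place of fluoro on this aromatic carbon gave no readable step on the piperazin-1-yl core, a 1.1-fold lower number from compound 3 to compound 4 (0.04 log units; within the scatter), and it compares closely with the step on the core of compound 1: the same change on two cores in this assay, a 1.4-fold lower number (0.14 log units; within the scatter) from compound 1 to compound 2 and a 1.1-fold lower number (0.04 log units; within the scatter) from compound 3 to compound 4, 1.3-fold (0.10 log units) apart, within the scatter of two such steps

The exchange of the amine carried over as well, since with chloro in place of fluoro, the same swap of 3-(aminomethyl)pyrrolidin-1-yl for piperazin-1-yl gave a 5.4-fold higher number from compound 2 to compound 4 (0.73 log units; beyond the scatter), and the two steps agree: the same change on two cores in this assay, a 4.3-fold higher number (0.63 log units; beyond the scatter) from compound 1 to compound 3 and a 5.4-fold higher number (0.73 log units; beyond the scatter) from compound 2 to compound 4, 1.3-fold (0.10 log units) apart, within the scatter of two such steps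

The two changes therefore behave as independent of each other in these four compounds, with the amine setting the number and the halogen leaving it within the scatter, but this rests on just two pairs for each change, in one assay, and it does not show that the same would hold for any other group or core.

The compounds shown leave open whether a hydrogen or a methoxy group on that aromatic carbon would also leave the number unchanged across the two cores. They also leave open whether the halogen stays without a readable step beside other amines, such as a morpholine ring or an open-chain amine.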